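Ring-substituent pattern on the phenoxy group of a sulfonamide series

A few compounds are considered here, and "the series" means these few. Any claim that something is new, unique, unknown or untested is made for them only; others in the source may bear on it.

Compound 2 `Cc1ccc(Oc2cc(F)cc(N3Cc4ccccc4S3(=O)=O)c2)cc1` is the lower of the two numbers recorded so far in a functional assay on Flp-In T-REx293 cells for antagonist activity at Free fatty acid receptor 1 (Homo sapiens), read by calcium flux; on this read-out higher numbers stand for weaker inhibition and lower numbers for stronger inhibition: compound 2 gives 2880 nM, while compound 1 `Cc1ccccc1Oc1cc(F)cc(N2Cc3ccccc3S2(=O)=O)c1` gives 44700 nM. Among the measured compounds shown here, the one measured step, a 16-fold lower number from compound 1 to compound 2 (1.19 log units; beyond the scatter), corresponds to 4-methylphenyl in place of 2-methylphenyl on an oxygen on an aromatic ring. Compound 3 `N#Cc1ccccc1Oc1cc(F)cc(N2Cc3ccccc3S2(=O)=O)c1` differs from compound 2 by 2-cyanophenyl in place of 4-methylphenyl on an oxygen on an aromatic ring. This step bears on the measured one only indirectly: it moves the substituent back to the 2-position of the phenyl, as in compound 1, but exchanges methyl for cyano, a change for which no comparison exists in the series. As far as these compounds go, because a 16-fold lower number from compound 1 to compound 2 (1.19 log units; beyond the scatter) was large, a return to a 2-substituted phenyl is expected to give a markedly higher number, though the cyano group is untested and the range is wide. Compound 3 is therefore expected to give 20000 nM (range 5000 nM to 80000 nM), a step of a 6.9-fold higher number from compound 2 to compound 3 (0.84 log units; beyond the scatter).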

Compound 3, half-maximal inhibitory concentration: > 100000 nM
Compound 3 gave a limit, no number; the forecaster's own chance of this, stated with the estimate: 20%; middle value at least 5.0-fold (0.69 log units) away from the limit.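

In this assay compound 3 gives a limit of the assay and not a number: the limit of > 100000 nM in this assay, at which 1 of the 3 values shown sits.

With 2-cyanophenyl in place of 4-methylphenyl, the change reads as an at least 34-fold higher number from compound 2 to compound 3 (1.54 log units; beyond the scatter), a step that is itself bounded and not exact. Cyano in place of methyl on the same aromatic carbon gives an at least 2.2-fold higher number from compound 1 to compound 3 (0.34 log units; beyond the scatter), so the two compounds carrying a 2-substituted phenyl now both lie well above compound 2, and the high numbers are no longer tied to methyl alone.

The compounds shown leave open whether 4-cyanophenyl would stay close to 4-methylphenyl, which would separate the identity of the group from its place on the ring. They also leave open how a carboxylic acid or an amine on the phenyl would read.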